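The compounds below may be only part of what the source reports. "The series", "measured", "known", "first", "only" and "open" are said of these compounds alone.

Working notes on the series. Compound 1 `C=C(C)[C@@H]1CC=C(Cn2cc(COc3ccc(C4NC(=O)NC(C)=C4C(=O)OCC)cc3)nn2)CC1` and compound 2 `C=C(C)[C@@H]1CC=C(Cn2cc(COc3cccc(C4NC(=O)NC(C)=C4C(=O)OCC)c3)nn2)CC1` are built from the same atoms joined differently; the difference between the two cores is not broken down here. Compound 3 `C=C(C)[C@@H]1CC=C(Cn2cc(COc3ccc(C4NC(=O)NC(C)=C4C(C)=O)cc3)nn2)CC1` is compound 1 carrying (methyl in place of ethoxy on a carbonyl carbon). In a functional assay on U-251 cells (Homo sapiens) for inhibition, read by sulforhodamine B assay, with a stated time of 48 h (on this read-out lower numbers stand for stronger inhibition of growth and higher numbers for weaker inhibition of growth), compound 1 gives 12400 nM, compound 2 gives 12200 nM and compound 3 gives 20000 nM. Among the compounds with values here, the one measured step on this change is a 1.6-fold higher number from compound 1 to compound 3 (0.21 log units; within the scatter). Compound 4 `C=C(C)[C@@H]1CC=C(Cn2cc(COc3cccc(C4NC(=O)NC(C)=C4C(C)=O)c3)nn2)CC1` has not been measured; it differs from compound 2 by methyl in place of ethoxy on a carbonyl carbon, the same kind of change at a place described in the same words. Compound 4 is expected to sit at 19000 nM in this assay, within 9000 nM to 40000 nM, because a 1.6-fold higher number from compound 1 to compound 3 (0.21 log units; within the scatter) suggests only a small shift. The step expected is a 1.6-fold higher number from compound 2 to compound 4 (0.19 log units; within the scatter).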

Compound 4, concentration for total growth inhibition: 30500 nM
Estimate against measurement, compound 4: 1.6-fold (0.21 log units) below; the measured number falls inside the stated range.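

Replacing ethoxy with methyl on the carbonyl carbon gives a 2.5-fold higher number from compound 2 to compound 4 (0.40 log units; beyond the scatter) in this assay. The two steps do not differ on this evidence, so the change carries from one core to the other as far as can be read here: the same change on two cores in this assay, a 1.6-fold higher number (0.21 log units; within the scatter) from compound 1 to compound 3 and a 2.5-fold higher number (0.40 log units; beyond the scatter) from compound 2 to compound 4, 1.6-fold (0.19 log units) apart, within the scatter of two such steps This rests on a single pair of cores in one assay, and it neither shows that the step would hold on any further core nor marks the core of compound 2 as more sensitive to the change.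

The compounds shown leave open how a carboxylic acid, an amide or a longer-chain ester on the same carbonyl carbon would read. Going by these compounds, whether the ethoxycarbonyl to acetyl change keeps its size in other cell lines also remains open.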